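Chloro in place of bromo: compound 3 to compound 4

The source may hold more compounds than are shown below. What is called first, only, known or untested is meant among the compounds shown, and "the series" means these compounds.

Measured so far in an ADME assay on Vero cells (Chlorocebus sabaeus) for cytotoxicity, read by MTT assay, with a stated time of 72 h; on this read-out lower numbers stand for higher toxicity in this test and higher numbers for lower toxicity in this test:
compound 1 `CC/C(=C\c1ccc(Cl)cc1)C(=O)/C=C/c1ccc([N+](=O)[O-])cc1`: 36000 nM
compound 2 `CC/C(=C\c1ccc(Cl)cc1)C(=O)/C=C/c1ccc(C=O)cc1`: 46900 nM
compound 3 `CC/C(=C\c1ccc(Cl)cc1)C(=O)/C=C/c1ccc(Br)cc1`: 29400 nM

Compound 3, at 29400 nM, stands within the scatter of both other compounds: a 1.2-fold lower number from compound 1 to compound 3 (0.09 log units; within the scatter) and a 1.6-fold lower number from compound 2 to compound 3 (0.20 log units; within the scatter). The next compound to be read is compound 4 `CC/C(=C\c1ccc(Cl)cc1)C(=O)/C=C/c1ccc(Cl)cc1`, which carries chloro in place of bromo on an aromatic carbon, para to a large group: chloro in place of bromo on an aromatic carbon.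

For the measured compounds named here, three measured steps bear on this change, since all exchange one group at this same place. Besides the two above, there is a 1.3-fold higher number from compound 1 to compound 2 (0.11 log units; within the scatter). All three lie within the scatter, even though nitro, formyl and bromo are quite different groups. Going by the values given here, none of the measured steps has chloro entering at this place, so the evidence is indirect. No step beyond the scatter is therefore expected in this assay. The expected step is a 1.1-fold higher number from compound 3 to compound 4 (0.05 log units; within the scatter). For compound 4 the estimated half-maximal cytotoxic concentration is 33000 nM, with an expected range of 19000 nM to 58000 nM.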

Compound 4, half-maximal cytotoxic concentration: 28300 nM
For compound 4 the middle estimate is 1.2-fold (0.07 log units) above the measured one, within the range that was stated.
By their numbers in this assay, from the lowest: compounds 4, 3, 1 and 2 (each within the scatter of the next).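

In this assay the exchange of one halogen for the other at this aromatic carbon gives a step within the scatter (a 1.0-fold lower number from compound 3 to compound 4 (0.02 log units; within the scatter)), so 4-bromophenyl and 4-chlorophenyl cannot be told apart in this test. Chloro, now read directly at this place, also stays within the scatter of the formyl and nitro compounds (a 1.7-fold lower number from compound 2 to compound 4 (0.22 log units; within the scatter); a 1.3-fold lower number from compound 1 to compound 4 (0.10 log units; within the scatter)), which extends the flat picture to four groups on the shared core. No measured evidence bears on why these groups read alike.

On these data alone, whether an amine or a carboxylic acid at this place would give a step beyond the scatter stays open. Also open, as far as these compounds go, is whether the same flat reading would hold on a changed core.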